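Changing the Ring on the Sulfonamide of Compound 1

A few compounds are considered here, and "the series" means these few. Any claim that something is new, unique, unknown or untested is made for them only; others in the source may bear on it.

For the measured compounds named here, in an ADME assay on the whole organism (Mus musculus, strain BALB/c), read by LC-MS, with a stated time of 24 h, at a dose of 10 mg/kg by the oral route (a lower number here means less compound in the circulation, a higher number more compound in the circulation at the dose given), compound 1 (`O=S(=O)(Nc1ncccn1)c1ccc2c(c1)OCC[C@@H]2c1ccc(C(F)(F)F)cc1-c1ccc(F)nc1`) gives 90700 ng.h/mL, the higher of the two numbers measured so far. Compound 2 (`Cn1nccc1-c1cc(C(F)(F)F)ccc1[C@H]1CCc2cc(S(=O)(=O)Nc3ncccn3)ccc21`) gives 42000 ng.h/mL, a gap beyond the usual scatter. Compound 3 (`O=S(=O)(Nc1nccs1)c1ccc2c(c1)OCC[C@@H]2c1ccc(C(F)(F)F)cc1-c1ccc(F)nc1`) keeps the core of compound 1 but carries 1,3-thiazol-2-yl in place of pyrimidin-2-yl on a sulfonamide nitrogen. Going by the values given here, no measured pair shows this change, so any expectation here is loose. A lower number is expected, with an estimated step of a 2.3-fold lower number from compound 1 to compound 3 (0.36 log units; beyond the scatter). The estimate for compound 3 is 40000 ng.h/mL, with an expected range of 12000 ng.h/mL to 110000 ng.h/mL.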

Compound 3, area under the concentration-time curve: 10200 ng.h/mL
The estimate for compound 3 lay 3.9-fold (0.59 log units) above the measured number; the whole stated range lies above it.
By their numbers in this assay, from the lowest: compound 3; then compound 2; then compound 1.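

With the rest of compound 1 unchanged, putting 1,3-thiazol-2-yl in place of pyrimidin-2-yl on the sulfonamide nitrogen gives an 8.9-fold lower number from compound 1 to compound 3 (0.95 log units; beyond the scatter) in this assay. For the compounds shown here, this is the only pair here that differs in one place, so it alone shows that the group on this nitrogen can move the number on its own. Nothing measured here explains the fall. Still open, on these data alone, is how a pyridin-2-yl or a 1,3-oxazol-2-yl group would behave on this nitrogen, and whether the same swap would have a similar effect on the core of compound 2.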